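The source may hold more compounds than are shown below. What is called first, only, known or untested is meant among the compounds shown, and "the series" means these compounds.

Compound 3 `COc1cc2cc(Oc3ccc(NC(=O)Nc4ccc(Cl)c(C(F)(F)F)c4)cc3)c(C)nc2cc1OC` stands lowest of the three measured compounds in a functional assay on HCT-116 cells (Homo sapiens) for inhibition, read by sulforhodamine B assay, with a stated time of 48 h, tested at 10 uM (a lower number here means a stronger effect, a higher number a weaker effect of the compound at the concentration tested), where compound 3 gives -87.3%. Compound 2 `COc1cc2cc(Oc3ccc(NC(=O)Nc4cccc(C(F)(F)F)c4)cc3)c(C)nc2cc1OC` gives 6.71% in this assay, and compound 1 `COc1cc2cc(Oc3ccc(NC(=O)Nc4ccc(C(F)(F)F)cc4)cc3)c(C)nc2cc1OC` gives 47.2%. All measured steps were large: a number 40.5 percentage points lower from compound 1 to compound 2 (beyond the scatter), a number 94 percentage points lower from compound 2 to compound 3 (beyond the scatter) and a number 134.5 percentage points lower from compound 1 to compound 3 (beyond the scatter). Compound 4 `COc1cc2cc(Oc3ccc(NC(=O)Nc4ccc(Cl)c(Cl)c4)cc3)c(C)nc2cc1OC` differs from compound 3 by chloro in place of trifluoromethyl on an aromatic carbon. Among the measured compounds shown here, no measured step shows chloro in place of trifluoromethyl; the measured steps only show that changes on this ring move the read-out strongly, the step from compound 2 to compound 3 being the nearest guide. Compound 4 is therefore expected to stay low, with an estimated step of a number 27.3 percentage points higher from compound 3 to compound 4 (beyond the scatter) whose direction is uncertain. Compound 4 is estimated at -60%, between -110% and 0%.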

Compound 4, a percentage reported as activity, at one concentration (the size of the read-out at that concentration, not a potency): 10.5%
Beside the measured number, compound 4's estimate is 70.5 percentage points below it; measured number above the stated range.
By their numbers in this assay, from the lowest: compound 3; then compounds 2 and 4 (each within the scatter of the next); then compound 1.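

In this assay, chloro in place of trifluoromethyl, ortho to a chloro group, brings a number 97.8 percentage points higher from compound 3 to compound 4 (beyond the scatter) and so removes most of what set compound 3 apart, showing that at this place the read-out depends on which group sits there and not only on a group being present. The 3,4-dichlorophenyl group gives a number 3.8 percentage points higher from compound 2 to compound 4 (within the scatter) and still a number 36.7 percentage points lower from compound 1 to compound 4 (beyond the scatter) in this series. Nothing measured here explains the change. From the compounds shown here alone, whether a nitrile or an amine at this place would hold the low read-out of compound 3 stays open.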